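A few compounds are considered here, and "the series" means these few. Any claim that something is new, unique, unknown or untested is made for them only; others in the source may bear on it.

Measured in a functional assay on LNCaP cells (Homo sapiens) for antiproliferative activity; on this read-out lower numbers stand for stronger inhibition and higher numbers for weaker inhibition:
- Compound 1 `CN1CCN(c2ccc(NC(=O)Nc3ccc(-c4nc(N5C6CCC5COC6)nc(N5[C@H](CO)CC[C@@H]5CO)n4)cc3)cc2)CC1`: < 0.8 nM, a limit of the assay
- Compound 2 `CC(C)Nc1nc(-c2ccc(NC(=O)Nc3ccc(N4CCN(C)CC4)cc3)cc2)nc(N2C3CCC2COC3)n1`: 50 nM

Among the compounds with values here, compound 2 holds the only actual number so far, since the other value is a limit. Compound 3 `CC(C)N(C)c1nc(-c2ccc(NC(=O)Nc3ccc(N4CCN(C)CC4)cc3)cc2)nc(N2C3CCC2COC3)n1` changes isopropylamino to isopropyl(methyl)amino, methyl in place of hydrogen on a nitrogen on an aromatic ring. Within the data shown here, the one measured step touching this substituent, an at least 62-fold higher number from compound 1 to compound 2 (1.79 log units; beyond the scatter), is large, but it exchanges the whole group and sets no size for a single methyl. In this assay the expected step is a 1.2-fold higher number from compound 2 to compound 3 (0.08 log units; within the scatter), within the scatter. Compound 3 is estimated at 60 nM, with an expected range of 15 nM to 250 nM.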

Compound 3, half-maximal inhibitory concentration: 240 nM
Compound 3: the middle estimate sits 4.0-fold (0.60 log units) below what was measured; measured number inside the range.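

In this assay, methyl in place of hydrogen on this nitrogen gives a 4.8-fold higher number from compound 2 to compound 3 (0.68 log units; beyond the scatter), so a single added carbon is enough to move the read-out beyond the scatter, a size the whole-group exchange could not set. Exchanging 2,5-bis(hydroxymethyl)pyrrolidin-1-yl for isopropyl(methyl)amino gives an at least 300-fold higher number from compound 1 to compound 3 (2.47 log units; beyond the scatter). That step is only a bound, and compound 1 holds a limit of the assay: the limit of < 0.8 nM in this assay, at which 1 of the 3 values shown sits.

From the compounds shown here alone, whether the hydrogen on this nitrogen itself matters, or only the size of the group replacing it, stays open. A smaller dimethylamino group or a 2-hydroxyethylamino group at this place would separate these readings.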